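The source may hold more compounds than are shown below. What is called first, only, known or untested is meant among the compounds shown, and "the series" means these compounds.

Measured compounds:
Compound 1 `Cn1c(-c2ccc(NC(=O)CSc3nc4ccccc4o3)cc2)nc(-c2ccccc2)c1-c1ccccc1` gives 56.2% in a functional assay on HT-29 cells (Homo sapiens) for cytotoxicity, read by MTT assay, with a stated time of 24 h, tested at 16 ug/mL; a higher number here means a stronger effect of the compound at the concentration tested, a lower number a weaker effect.
Compound 2 `Cn1cnnc1SCC(=O)Nc1ccc(-c2nc(-c3ccccc3)c(-c3ccccc3)n2C)cc1` gives 59.1% in this assay.

Both compounds share a core that ends in a sulfur on a saturated chain carbon, and that sulfur carries a small aromatic group. Compound 1 and compound 2 differ only in that group, and the step of a number 2.9 percentage points higher from compound 1 to compound 2 (within the scatter) lies within the scatter, so the two numbers cannot be told apart; compound 1 merely shows the lower of the two. Compound 3 `Cn1nnnc1SCC(=O)Nc1ccc(-c2nc(-c3ccccc3)c(-c3ccccc3)n2C)cc1` has not been measured. It differs from compound 1 in the same place: 1-methyl-1H-tetrazol-5-yl in place of 1,3-benzoxazol-2-yl on a sulfur. Among the compounds with values here, the only measured step that bears on this change is the one between compound 1 and compound 2, where another small ring entered the same place and the number did not move beyond the scatter. The same outcome is expected here, a step of a number 0.8 percentage points higher from compound 1 to compound 3 (within the scatter) in this assay, nothing beyond the scatter. Compound 3 is therefore estimated at 57%, between 45% and 69%.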

Compound 3, a percentage reported as activity, at one concentration (the size of the read-out at that concentration, not a potency): 72.5%
For compound 3 the middle estimate is 15.5 percentage points below the measured one; measured number above the stated range.
By their numbers in this assay, from the lowest: compounds 1 and 2 (each within the scatter of the next); then compound 3.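

With 1-methyl-1H-tetrazol-5-yl on the sulfur, the number in this assay clears the scatter against both 1,3-benzoxazol-2-yl (a number 16.3 percentage points higher from compound 1 to compound 3 (beyond the scatter)) and 4-methyl-4H-1,2,4-triazol-3-yl (a number 13.4 percentage points higher from compound 2 to compound 3 (beyond the scatter)). This position is therefore not indifferent to which ring it carries, something the pair of compound 1 and compound 2 alone could not show, and one five-membered ring cannot simply be assumed to behave like another here. Nothing at hand explains why this ring stands apart.

Going by these compounds, it remains open whether the methyl on the ring matters, for instance what an ethyl in its place would do, and how an open chain such as an aminoethyl group on the sulfur would compare. Also open, on these data alone, is how these steps would look as potencies, as the read-out comes from a single concentration.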